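Substituted cycloalkyl amides on the alkynyl thiazole core

The source may report more compounds than this note shows. Statements on the series, on what has been measured and on what is new or still open speak of the compounds shown alone.

Measured compounds:
- compound 1, `O=C(C1CCC1)N1CCc2nc(C#Cc3ccccc3)sc2C1`, 370 nM
- compound 2, `CC1CC(C(=O)N2CCc3nc(C#Cc4ccccc4)sc3C2)C1`, > 10000 nM
- compound 3, `O=C(C1CC(F)C1)N1CCc2nc(C#Cc3ccccc3)sc2C1`, > 10000 nM

In an assay on HEK293 cells for negative allosteric modulation of metabotropic glutamate receptor 5 (Homo sapiens), read by FLIPR, with a stated time of 1 h (on this read-out higher numbers stand for weaker inhibition and lower numbers for stronger inhibition), compound 1, the unsubstituted cyclobutyl amide, gives 370 nM. Compound 2 reaches only the limit of the assay, > 10000 nM. Compound 3 likewise stops at the limit, > 10000 nM. Both substituted cyclobutyl analogues therefore sit at the limit of > 10000 nM in this assay, at which 2 of the 3 values shown sit, and compound 3 stands at the weak end of the numbers shown, with an at least 27-fold higher number from compound 1 to compound 3 (1.43 log units; beyond the scatter) and an at least 27-fold higher number from compound 1 to compound 2 (1.43 log units; beyond the scatter) both large losses, while a step that the two limits leave unreadable from compound 2 to compound 3 cannot be read.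

Compound 4, `CC1CCC(C(=O)N2CCc3nc(C#Cc4ccccc4)sc3C2)CC1`, is not yet measured. The change is 4-methylcyclohexyl in place of 3-fluorocyclobutyl on a carbonyl carbon. Among the measured compounds shown here, no measured step tracks a change of ring size on the amide; the two steps that come closest, both from compound 1, show that putting either a methyl or a fluoro on the saturated ring costs a large amount. Compound 4 again carries a methyl on a saturated ring, so a weak result is expected and a number no higher from compound 3 to compound 4 (the limit leaves the size open) is estimated to stay close to the limit. For compound 4 the expected value in this assay is 10000 nM, with a range from 2000 nM to 50000 nM.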

Compound 4, half-maximal inhibitory concentration: > 10000 nM
Compound 4 was reported as a limit; the forecaster's own chance of this, stated with the estimate: 60%; the middle value sits exactly at the limit.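

On the carbonyl carbon, the large loss is no longer confined to the four-membered ring: a six-membered ring carrying a methyl gives an at least 27-fold higher number from compound 1 to compound 4 (1.43 log units; beyond the scatter), and the 4-methylcyclohexyl group joins the 3-methylcyclobutyl and 3-fluorocyclobutyl groups among the amides without a measured number. The result for compound 4 is a limit, as are those for compound 2 and compound 3, so the steps among these three cannot be read and no order among them can be given. In this assay, the plain cyclobutyl amide, compound 1, is the only one of the four with a measured number, and the rest of the set gathers at one limit: the limit of > 10000 nM in this assay, at which 3 of the 4 values shown sit.

The 4-methylcyclohexyl group differs from cyclobutyl in both ring size and the added methyl, and the compounds shown include no unsubstituted cyclopentyl or cyclohexyl amide that would separate these two changes. Also open, as far as these compounds go, is whether any substituent on the cyclobutyl ring, such as a hydroxyl or an amine, would keep a measured number rather than a limit.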